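Swapping diethylamino for dipropylamino in compound 3

The source may report more compounds than this note shows. Statements on the series, on what has been measured and on what is new or still open speak of the compounds shown alone.

Measured so far in a functional assay on DU-145 cells (Homo sapiens) for antiproliferative activity, read by WST assay, with a stated time of 3 days; on this read-out higher numbers stand for weaker inhibition and lower numbers for stronger inhibition
Compound 1 `CCCOc1c(-c2cc(OC)c(OC)c(OC)c2)oc2ccccc2c1=O` gives 2800 nM
Compound 2 `CCC(C)Oc1c(-c2cc(OC)c(OC)c(OC)c2)oc2ccccc2c1=O` gives > 50000 nM as a limit of the assay, not a number
Compound 3 `CCN(CC)CCCCOc1c(-c2cc(OC)c(OC)c(OC)c2)oc2ccccc2c1=O` gives 13300 nM

Only two of these results are true numbers, and compound 3 has the higher one, which means weaker inhibition than compound 1. The gap between them is a 4.8-fold higher number from compound 1 to compound 3 (0.68 log units; beyond the scatter) and comes with the added amino chain. Compound 2 has only a limit. Against that limit, the measured step is an at least 3.7-fold lower number from compound 2 to compound 3 (0.57 log units; beyond the scatter) and places compound 3 on the stronger side.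

Compound 4 `CCCN(CCC)CCCCOc1c(-c2cc(OC)c(OC)c(OC)c2)oc2ccccc2c1=O` changes only the end of the chain (dipropylamino in place of diethylamino on a saturated chain carbon, four bonds along the chain from an oxygen on an aromatic ring). In words, dipropylamino stands in place of diethylamino, on a saturated chain carbon, four bonds along the chain from an oxygen on an aromatic ring.

The step of an at least 17-fold higher number from compound 1 to compound 2 (1.25 log units; beyond the scatter) shows that one added methyl can matter greatly in this series, but it sits at a different place. Among the measured compounds shown here, none of the measured steps swaps one amino group for another, so they give no direct size for this change. In this assay no step beyond the scatter is expected, though the spread of those steps calls for a broad range. The expected change is a 1.0-fold lower number from compound 3 to compound 4 (0.01 log units; within the scatter) and no direction is favoured. For compound 4 the expected value is 13000 nM with a range of 4500 nM to 38000 nM as the estimate.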

Compound 4, half-maximal inhibitory concentration: 35800 nM
Compound 4: the middle estimate sits 2.8-fold (0.44 log units) below what was measured; the range from low to high includes it.
By their numbers in this assay, from the lowest: compound 1; then compound 3; then compound 4. At a limit, above all of these: compound 2.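

In this assay, a 2.7-fold higher number from compound 3 to compound 4 (0.43 log units; beyond the scatter) gives the first direct sign that the groups on the chain-end nitrogen matter on their own, with dipropylamino giving weaker inhibition than diethylamino at this place. Measured against the plain propyl ether, a 13-fold higher number from compound 1 to compound 4 (1.11 log units; beyond the scatter), and compound 3 lies on the same side with a 4.8-fold higher number from compound 1 to compound 3 (0.68 log units; beyond the scatter), so both amino chains shown give weaker inhibition than compound 1. Compound 2 carries only a limit of the assay, not a true number, so an at least 1.3-fold lower number from compound 2 to compound 4 (0.14 log units; that floor lies within the scatter) does not settle any order for that pair, and the comparison stays open-ended: the limit of > 50000 nM in this assay, at which 1 of the 4 values shown sits.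

On these data alone, two amines give a direction for this pair only, so it remains open whether a smaller dimethylamino group would give lower numbers, or whether a ring amine such as piperidine or morpholine would behave like either open chain. As far as these compounds go, it is also open whether the gap between diethylamino and dipropylamino would hold on a shorter chain, as in 3-(diethylamino)propyl and 3-(dipropylamino)propyl, or on a longer one.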